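The source may hold more compounds than are shown below. What is called first, only, known or untested is meant among the compounds shown, and "the series" means these compounds.

- compound 1 `C=C[C@@](C)(/C=C/c1ccc(OC(C)=O)cc1)CCC=C(C)C`: 75%
- compound 2 `C=C[C@@](C)(/C=C/c1ccc(OC(=O)CCC)cc1)CCC=C(C)C`: 20%
- compound 3 `C=C[C@@](C)(/C=C/c1ccc(OC(=O)CCCCCCCCCCCCCCC)cc1)CCC=C(C)C`: 24%

All three values come from a functional assay on MCF7 cells (Homo sapiens) for inhibition, with a stated time of 48 h, tested at 50 uM; on this read-out higher numbers stand for more inhibition of growth at the one concentration tested and lower numbers for less inhibition of growth. Compound 2, at 20%, sits at the low end of this small set. The comparison with its neighbours reads a number 4 percentage points higher from compound 2 to compound 3 (within the scatter), and on the other side a number 55 percentage points lower from compound 1 to compound 2 (beyond the scatter).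

The next compound is compound 4 `C=C[C@@](C)(/C=C/c1ccc(OC)cc1)CCC=C(C)C`, which has methyl in place of propylcarbonyl on an oxygen on an aromatic ring. The same change can be read as (propylcarbonyl)oxy to methoxy, so the carbonyl is lost.

Neither measured step removes that carbonyl. Both alter only the chain attached to it, so neither measures this change directly. The closest guide is compound 1, which also carries a small group at this oxygen and reaches 75%. Compound 3 offers no trend to extend, since its much longer chain leaves it within the scatter of compound 2. One large step is thin evidence, so a rise is expected in this assay, but probably not the full gap to compound 1. The expected size is a number 25 percentage points higher from compound 2 to compound 4 (beyond the scatter). Compound 4 is estimated at 45%, with an expected range of 20% to 75%.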

Compound 4, percent growth inhibition at one concentration: 18%
Beside the measured number, compound 4's estimate is 27 percentage points above it; the measured number lies below the stated range.
By their numbers in this assay, from the lowest: compounds 4, 2 and 3 (each within the scatter of the next); then compound 1.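

In this assay, removing the carbonyl at this oxygen makes no measurable difference against the longer ester: the step is a number 2 percentage points lower from compound 2 to compound 4 (within the scatter), so methoxy and (propylcarbonyl)oxy cannot be told apart here. The second step, a number 57 percentage points lower from compound 1 to compound 4 (beyond the scatter), shows that having few atoms on this oxygen is not enough for strong growth inhibition, as methyl carries fewer atoms than acetyl and still gives a far lower number, which leaves acetyl as the only group shown here that goes with a high value. Nothing in the available data explains why acetyl stands apart from methyl and propylcarbonyl on this oxygen.

Going by these compounds, it remains open how a free hydroxyl group or a propionyl group on this oxygen would compare with acetyl, and so whether the high number belongs to acetyl alone or extends to close relatives. On these data alone, it is also open whether the value of 75% for compound 1 would hold at lower concentrations, as this read-out rests on a single concentration.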